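Triazole series: methoxy to trifluoromethyl on the aryl ring

The source may hold more compounds than are shown below. What is called first, only, known or untested is meant among the compounds shown, and "the series" means these compounds.

Compound 1 `C=C1C[C@]23C[C@@]1(O)CC[C@@H]2c1cccc(C)c1[C@@H]3Cn1cc(-c2ccc(OC)cc2)nn1` was run in a functional assay on SMMC-7721 cells (Homo sapiens) for cytotoxicity, read by MTT assay, with a stated time of 4 days (on this read-out higher numbers stand for weaker inhibition and lower numbers for stronger inhibition), and returns only a limit, > 20000 nM. Compound 2 `C=C1C[C@]23C[C@@]1(O)CC[C@H]2c1ccc(O)c(C)c1[C@@H]3Cn1cc(-c2ccccc2)nn1` also returns only a limit in this assay, > 20000 nM. Compound 1 thus stands at the limit of > 20000 nM in this assay, at which 2 of the 2 values shown sit, with no number to place it against. Compound 3 `C=C1C[C@]23C[C@@]1(O)CC[C@@H]2c1cccc(C)c1[C@@H]3Cn1cc(-c2ccc(C(F)(F)F)cc2)nn1` carries the change (trifluoromethyl in place of methoxy on an aromatic carbon), trifluoromethyl in place of methoxy on an aromatic carbon. Among the measured compounds shown here, no measured step covers this change, so no shift beyond the scatter is expected in this assay, and compound 3 is expected to return a limit again. The estimate for compound 3 is 25000 nM, in the range 8000 nM to 80000 nM. The step that the limit leaves unreadable from compound 1 to compound 3 is expected to be small.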

Compound 3, half-maximal inhibitory concentration: > 20000 nM
Compound 3: a limit, no number; the forecaster's own chance of this, stated with the estimate: 75%; the middle value lies beyond the limit too.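

Compound 3 returns only a limit, > 20000 nM, and compound 1 also stands at a limit, so no step can be read between compound 1 and compound 3. The compounds shown leave open which change, if any, would give a measurable number in this assay.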